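A few compounds are considered here, and "the series" means these few. Any claim that something is new, unique, unknown or untested is made for them only; others in the source may bear on it.

Measured so far:
compound 1, `CC(C)(N)CC(=O)N[C@@H]1CCc2ccccc2N(Cc2ccc(-c3ccccc3-c3nc[nH]n3)cc2)C1=O`, with 90 nM;
compound 2, `COc1nsnc1-c1ccccc1-c1ccc(CN2C(=O)[C@H](NC(=O)CC(C)(C)N)CCc3ccccc32)cc1`, with 1800 nM;
compound 3, `CC(C)(N)CC(=O)N[C@@H]1CCc2ccccc2N(Cc2ccc(-c3cccnc3-c3nn[nH]n3)cc2)C1=O`, with 2350 nM.

All three were tested in a functional assay (Pituitary gland cell) with Rattus norvegicus as the target; on this read-out higher numbers stand for an effect only at larger amounts of compound and lower numbers for an effect already at smaller amounts. Compound 3 has the highest of the three numbers. Compound 2 lies close to it, and the two values do not differ by more than the usual scatter. Compound 1 stands far apart: the change from compound 1 to compound 3 gave a 26-fold higher number from compound 1 to compound 3 (1.42 log units; beyond the scatter), a large step in this assay.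

Compound 4, `Cc1nnc(-c2cscc2-c2ccc(CN3C(=O)[C@H](NC(=O)CC(C)(C)N)CCc4ccccc43)cc2)o1`, is not yet measured. It differs from compound 3 in one place: 4-(5-methyl-1,3,4-oxadiazol-2-yl)thiophen-3-yl in place of 2-(2H-tetrazol-5-yl)pyridin-3-yl on an aromatic carbon. Both measured steps concern this same position. Besides the step just described, the change from compound 1 to compound 2 gave a 20-fold higher number from compound 1 to compound 2 (1.30 log units; beyond the scatter). Within the data shown here, both replacements of the group on that ring produced large rises, but neither starts from compound 3, so no measured step shows what the move from compound 3 to compound 4 will do. Compound 2 and compound 3 carry different groups at this position and sit within the scatter of each other, which suggests a modest change at most. The step from compound 3 to compound 4 in this assay is therefore expected to be a 1.2-fold lower number from compound 3 to compound 4 (0.07 log units; within the scatter). For compound 4 in this assay the estimate is 2000 nM, expected to fall between 600 nM and 7000 nM.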

Compound 4, half-maximal effective concentration: 125 nM
Compound 4: middle estimate off by 16-fold (1.20 log units), on the high side; measured number below the stated range.
By their numbers in this assay, from the lowest: compounds 1 and 4 (each within the scatter of the next); then compounds 2 and 3 (each within the scatter of the next).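

In this assay, the change at this aromatic carbon can also go the other way: replacing 2-(2H-tetrazol-5-yl)pyridin-3-yl with 4-(5-methyl-1,3,4-oxadiazol-2-yl)thiophen-3-yl gives a 19-fold lower number from compound 3 to compound 4 (1.27 log units; beyond the scatter), even though the leaving and entering groups hold equally many heavy atoms. The same entering group, set against the group in compound 1, gives a 1.4-fold higher number from compound 1 to compound 4 (0.14 log units; within the scatter), so a large rise is not the outcome of every replacement at this position, and a group with 0 hydrogen-bond donors can stay within the scatter of compound 1. No experimental evidence is available that bears on the reason for this result.

Going by these compounds, compound 3 and compound 4 differ in both rings of the group at once, so what each ring contributes separately remains open. On these data alone, how a simple amine or a carboxylic acid at this position would read out also remains open.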